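A few compounds are considered here, and "the series" means these few. Any claim that something is new, unique, unknown or untested is made for them only; others in the source may bear on it.

Two compounds were measured in a functional assay on MGC-803 cells (Homo sapiens) for inhibition, read by MTT assay, with a stated time of 72 h; on this read-out higher numbers stand for weaker inhibition and lower numbers for stronger inhibition:

Compound 1, `CC(C)c1ccc(-c2nc(SCc3cn(CC(=O)NC(=O)Nc4ccccn4)nn3)nc(Nc3cccc(Cl)c3)c2C#N)cc1`, gives > 64000 nM, which is a limit of the assay and not a number.
Compound 2, `COc1ccc(Nc2nc(SCc3cn(CC(=O)NC(=O)Nc4ccccn4)nn3)nc(-c3ccc(C)cc3)c2C#N)cc1`, gives 1700 nM.

Compound 2 holds the only numerical result in this assay; the other result is the limit of compound 1, (the limit of > 64000 nM in this assay, at which 1 of the 2 values shown sits). Compound 3, `Cc1ccc(-c2nc(SCc3cn(CC(=O)NC(=O)Nc4ccccn4)nn3)nc(Nc3cccc(Cl)c3)c2C#N)cc1`, differs from compound 2 in one place: 3-chlorophenyl in place of 4-methoxyphenyl on a nitrogen on an aromatic ring. Going by the values given here, no measured pair shows this exchange on its own, so the size of the step is not known from the data. Compound 1, which carries the same 3-chlorophenyl on that nitrogen, sits at the limit of the assay, while compound 2 gives a number. On this basis compound 3 is expected to be a weaker inhibitor than compound 2, with an expected step of a 7.1-fold higher number from compound 2 to compound 3 (0.85 log units; beyond the scatter) in this assay. The estimate for compound 3 is 12000 nM, within a range of 3000 nM to 50000 nM.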

Compound 3, half-maximal inhibitory concentration: 7890 nM
For compound 3 the middle estimate is 1.5-fold (0.18 log units) above the measured one, within the range that was stated.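

In this assay, the exchange on the nitrogen now has a size: a 4.6-fold higher number from compound 2 to compound 3 (0.67 log units; beyond the scatter). Compound 3 thus reads weaker with 3-chlorophenyl than compound 2 does with 4-methoxyphenyl, yet 3-chlorophenyl on that nitrogen still allows a number when methyl sits on the aromatic carbon. With 3-chlorophenyl held constant, methyl in place of isopropyl gives an at least 8.1-fold lower number from compound 1 to compound 3 (0.90 log units; beyond the scatter), and this step is only a bound, since compound 1 stands at a limit of the assay and not at a number: the limit of > 64000 nM in this assay, at which 1 of the 3 values shown sits.

The compounds shown leave open how large the nitrogen exchange would be with isopropyl on the aromatic carbon. They also leave open how a plain phenyl or a cyclohexyl group on that nitrogen would read.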